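The source may report more compounds than this note shows. Statements on the series, on what has been measured and on what is new or still open speak of the compounds shown alone.

Measured in a functional assay on SW-620 cells (Homo sapiens) for inhibition, read by sulforhodamine B assay, with a stated time of 48 h; a lower number here means a stronger inhibitor of growth, a higher number a weaker inhibitor of growth:
Compound 1 `Cc1ccc(NC(=O)/C=C/c2ccccc2)c(C(N)=O)c1`: 3300 nM
Compound 2 `NC(=O)c1cc(Br)ccc1NC(=O)/C=C/c1ccccc1`: 705 nM

Of these two compounds, compound 2 stands lowest, at 705 nM. Compound 3 `NC(=O)c1cc(I)ccc1NC(=O)/C=C/c1ccccc1` departs from it in one place: iodo in place of bromo on an aromatic carbon. In words, this is iodo in place of bromo on an aromatic carbon, the same carbon that changed between the two measured compounds. For the measured compounds named here, only one measured step bears on this change: a 4.7-fold lower number from compound 1 to compound 2 (0.67 log units; beyond the scatter), with bromo in place of methyl. A single step sets no trend, and it involved a different pair of groups. The swap of bromo for iodo is therefore expected to move the number in this assay by less than that step, slightly downward if at all. The expected change is a 1.3-fold lower number from compound 2 to compound 3 (0.12 log units; within the scatter). For compound 3 the estimated value is 540 nM, with an expected range of 220 nM to 1300 nM.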

Compound 3, concentration for 50% growth inhibition: 541 nM
Compound 3: the middle estimate sits 1.0-fold (0.00 log units) below what was measured; low and high end bracket the measured number.
By their numbers in this assay, from the lowest: compounds 3 and 2 (each within the scatter of the next); then compound 1.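

In this assay, moving from bromo to iodo on this carbon, meta to a carbamoyl group, gives (a 1.3-fold lower number from compound 2 to compound 3 (0.11 log units; within the scatter)), so the two halogens cannot be told apart at this position. Iodo in place of methyl gives (a 6.1-fold lower number from compound 1 to compound 3 (0.79 log units; beyond the scatter)), a step beyond the scatter that is of similar size to the one for bromo in place of methyl (a 4.7-fold lower number from compound 1 to compound 2 (0.67 log units; beyond the scatter)), so both halogens, and not bromo alone, stand apart from methyl in these three compounds. No measurement is available that explains this result.

The compounds shown leave open how a fluoro, a chloro or an amine on this carbon would read. They also leave open whether the gap between the halogens and methyl would persist if a carboxylic acid took the place of the carbamoyl group.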